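Swapping a Bromophenyl for a Fluorophenyl on the Core

The source may report more compounds than this note shows. Statements on the series, on what has been measured and on what is new or still open speak of the compounds shown alone.

Three compounds share one core and differ only in the aryl group attached to it. Compound 1 `c1cn2cc(-c3ccsc3)nc(-c3ccc4ncn(C5CCCCC5)c4c3)c2n1` carries a thiophen-3-yl group, and in a functional assay on ACHN cells (Homo sapiens) for inhibition, read by sulforhodamine B assay, with a stated time of 48 h, tested at 10 uM (a lower number here means less inhibition, a higher number more inhibition at the concentration tested (going by the name of the read-out)), compound 1 gives 5.76%. Compound 2 `CC(=O)c1ccc(-c2cn3ccnc3c(-c3ccc4ncn(C5CCCCC5)c4c3)n2)cc1` carries a 4-acetylphenyl group, and in this assay compound 2 gives 4.32%; the step of a number 1.4 percentage points lower from compound 1 to compound 2 (within the scatter) stays within the scatter. Compound 3 `Brc1ccc(-c2cn3ccnc3c(-c3ccc4ncn(C5CCCCC5)c4c3)n2)cc1` carries a 4-bromophenyl group, and in this assay compound 3 gives 21.4%, the highest of the three numbers, with a number 15.6 percentage points higher from compound 1 to compound 3 (beyond the scatter) and a number 17.1 percentage points higher from compound 2 to compound 3 (beyond the scatter) both beyond the scatter.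

Going by the values given here, compound 4 `Fc1ccccc1-c1cn2ccnc2c(-c2ccc3ncn(C4CCCCC4)c3c2)n1` is the untested member. 2-fluorophenyl in place of 4-bromophenyl on an aromatic carbon No measured step exchanges these two groups directly. The two steps that end at compound 3, a number 15.6 percentage points higher from compound 1 to compound 3 (beyond the scatter) and a number 17.1 percentage points higher from compound 2 to compound 3 (beyond the scatter), show that the 4-bromophenyl group stands apart from the other aryl groups tried, each of which sits near the bottom of the range. With the 4-bromophenyl group removed, compound 4 is expected to fall back toward the lower levels already seen, a step of a number 12.4 percentage points lower from compound 3 to compound 4 (beyond the scatter) downward beyond the scatter. Compound 4 is therefore estimated at 9%, with a range from 0% to 25%.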

Compound 4, a percentage reported as inhibition, at one concentration (the size of the read-out at that concentration, not a potency): 13.2%
Estimate against measurement, compound 4: 4.2 percentage points below; the measured number falls inside the stated range.
By their numbers in this assay, from the lowest: compounds 2, 1, 4 and 3 (each within the scatter of the next, the first and the last beyond it).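

In this assay, the 2-fluorophenyl group cannot be told apart from any of the other three aryl groups: the step of a number 8.2 percentage points lower from compound 3 to compound 4 (within the scatter) and the step of a number 8.9 percentage points higher from compound 2 to compound 4 (within the scatter) and the step of a number 7.4 percentage points higher from compound 1 to compound 4 (within the scatter) all stay close enough to count as no clear difference. Compound 3 still stands clear of compound 1 and compound 2, but compound 4 now sits within reach of both ends of that gap, so the earlier picture of one bromophenyl group set apart from a low group of neighbours becomes less sharp. This single swap changes both the halogen and where it sits on the phenyl ring, and nothing available explains the result or says which of the two changes counts.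

A 4-fluorophenyl or a 2-bromophenyl group on the shared core would separate the halogen from its place on the ring. A phenyl ring carrying an amine or a carboxylic acid remains an open question at this position, as does whether any of these aryl groups would give a larger inhibition reading than those seen so far.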